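Swapping the ring nitrogen's aryl group for a fluorophenyl

The compounds below may be only part of what the source reports. "The series", "measured", "known", "first", "only" and "open" are said of these compounds alone.

Three compounds share one core and differ only in the aryl group on the ring nitrogen. In a functional assay on 143B cells (Homo sapiens) for inhibition, read by CCK-8 assay, with a stated time of 72 h, tested at 1 uM (on this read-out higher numbers stand for more inhibition at the one concentration tested (going by the name of the read-out) and lower numbers for less inhibition), compound 1 `COc1ccc(C)cc1N1C(=O)CSC1c1cccc(C(=O)NCCCCc2ccccc2)c1` gives 29%, compound 3 `COc1cccc(OC)c1N1C(=O)CSC1c1cccc(C(=O)NCCCCc2ccccc2)c1` gives 31%, and compound 2 `COc1ccc(OC)c(N2C(=O)CSC2c2cccc(C(=O)NCCCCc3ccccc3)c2)c1` gives 2%. The step of a number 2 percentage points higher from compound 1 to compound 3 (within the scatter) lies within scatter, whereas a number 27 percentage points lower from compound 1 to compound 2 (beyond the scatter) and a number 29 percentage points higher from compound 2 to compound 3 (beyond the scatter) show that this aryl group can move the read-out by a modest amount. Compound 4 `O=C(NCCCCc1ccccc1)c1cccc(C2SCC(=O)N2c2cccc(F)c2)c1` carries the change (3-fluorophenyl in place of 2-methoxy-5-methylphenyl on an amide-type nitrogen in a ring). Going by the values given here, no measured step involves a fluorine or removes the methoxy, so the direction is uncertain; a move of roughly the size seen in the measured steps, either way, is plausible. The expected step is a number 9 percentage points lower from compound 1 to compound 4 (within the scatter), giving an estimate of 20% for compound 4, between 0% and 45%.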

Compound 4, a percentage reported as inhibition, at one concentration (the size of the read-out at that concentration, not a potency): 63%
Compound 4: middle estimate off by 43 percentage points, on the low side; measured number outside the range, above it.
By their numbers in this assay, from the lowest: compound 2; then compounds 1 and 3 (each within the scatter of the next); then compound 4.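

In this assay, the aryl group on the ring nitrogen can move the read-out further than the methoxy-bearing groups showed, with a number 34 percentage points higher from compound 1 to compound 4 (beyond the scatter), a number 32 percentage points higher from compound 3 to compound 4 (beyond the scatter) and a number 61 percentage points higher from compound 2 to compound 4 (beyond the scatter). The 3-fluorophenyl compound stands clearly above all three methoxy-bearing compounds, yet this swap adds a fluorine and removes the methoxy groups together. Nothing available explains the rise.

Going by these compounds, whether the fluorine or the loss of methoxy matters more stays open. A plain phenyl or a 3-chlorophenyl group on the same nitrogen would help to separate the two.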